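Cyclohexyl for dimethoxyphenyl: cytotoxicity on Vero cells

The source may hold more compounds than are shown below. What is called first, only, known or untested is meant among the compounds shown, and "the series" means these compounds.

Compound 1 `O=c1cc(Nc2ccccc2)sc2c([N+](=O)[O-])cc(C(F)(F)F)cc12` gives in an ADME assay on Vero cells (Chlorocebus sabaeus) for cytotoxicity, read by MTT assay, with a stated time of 48 h; a higher number here means a weaker inhibitor, a lower number a stronger inhibitor > 64 ug/mL, which is a limit of the assay rather than a number.
Compound 2 `COc1ccc(CNc2cc(=O)c3cc(C(F)(F)F)cc([N+](=O)[O-])c3s2)cc1OC` gives in this assay > 64 ug/mL, again a limit.

Compound 2 thus stands where every value shown stands: the limit of > 64 ug/mL in this assay, at which 2 of the 2 values shown sit. Among the measured compounds shown here, no step between measured compounds is available. Compound 3 `O=c1cc(NCC2CCCCC2)sc2c([N+](=O)[O-])cc(C(F)(F)F)cc12` differs from compound 2 by cyclohexyl in place of 3,4-dimethoxyphenyl on a saturated chain carbon bound to a nitrogen on an aromatic ring. In this assay the step from compound 2 to compound 3 is expected to be none beyond the usual scatter, because the limit of > 64 ug/mL in this assay, at which 2 of the 2 values shown sit, is where both known values lie. Compound 3 is therefore expected to give 64 ug/mL in this assay, between 32 ug/mL and 128 ug/mL, an expected step of a number no higher from compound 2 to compound 3 (the limit leaves the size open).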

Compound 3, half-maximal inhibitory concentration: > 64 ug/mL
Compound 3: no number, only a limit; the forecaster's own chance of this, stated with the estimate: 80%; the middle value sits exactly at the limit.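

Among the compounds shown here, compound 3 gives only a limit in this assay, as do compound 1 and compound 2, so no step among them can be read. The compounds shown leave open how far beyond that limit each one's true value lies.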